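The source may report more compounds than this note shows. Statements on the series, on what has been measured and on what is new or still open speak of the compounds shown alone.

Measured compounds in a functional assay on HEK293 cells (Homo sapiens) for cytotoxicity; on this read-out higher numbers stand for lower toxicity in this test and lower numbers for higher toxicity in this test:

- compound 1 `COc1ccc([C@H]2CC(=O)N(c3ccccc3C)C2)cc1OC1CCCC1` — in this assay compound 1 gives > 10000 nM, which is a limit of the assay and not a number.
- compound 2 `COc1ccc([C@H]2CC(=O)N(c3cccnc3)C2)cc1OC1CCCC1` — compound 2 gives > 10000 nM, again a limit.
- compound 3 `COc1ccc([C@H]2CC(=O)N(c3cccc(NCCCc4ccccc4)c3)C2)cc1OC1CCCC1` — compound 3 gives > 10000 nM, also a limit.

All three values shown sit at the same limit, as summarised in the limit of > 10000 nM in this assay, at which 3 of the 3 values shown sit. Going by the values given here, the one step between measured compounds that differ in a single place, a step that the two limits leave unreadable from compound 1 to compound 2, is therefore unreadable in size and direction. Compound 3 stands exactly where the other two stand: at the limit, with no number to rank it.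

Compound 4 `COc1ccc([C@H]2CC(=O)N(c3cccc(NS(=O)(=O)c4ccccc4Br)c3)C2)cc1OC1CCCC1` is the next compound to go into this assay. It differs from compound 3 as follows: (2-bromophenyl)sulfonyl in place of 3-phenylpropyl on a nitrogen on an aromatic ring. No measured step bears on this change, since the only step shown is unreadable; the sole guidance is that every value in the series has come back at the limit, per (the limit of > 10000 nM in this assay, at which 3 of the 3 values shown sit).

The step from compound 3 to compound 4 is expected to be a number no higher from compound 3 to compound 4 (the limit leaves the size open), that is, nothing beyond the scatter. Compound 4 is expected to give 10000 nM, with a range from 5000 nM to 30000 nM, and most likely to return only a limit.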

Compound 4, half-maximal cytotoxic concentration: > 10000 nM
Compound 4 ended at the assay's limit (the forecaster's own chance of this, stated with the estimate: 80%); the middle value lies on the limit itself.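

The change from compound 3 to compound 4 gives no readable step, both values being limits of the assay and not numbers. The compounds shown leave open how their cytotoxicity ranks and whether any single change in the series would shift it: the limit of > 10000 nM in this assay, at which 4 of the 4 values shown sit.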